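Halophenyl amides: the step to compound 4

A few compounds are considered here, and "the series" means these few. Any claim that something is new, unique, unknown or untested is made for them only; others in the source may bear on it.

- compound 1 `CN(C)C(=O)c1cc2cnc(Nc3ccc(NC(=O)C4(C(=O)Nc5ccc(F)cc5)CC4)cc3)nc2n1C1CCCC1`: 36.5%
- compound 2 `CN(C)C(=O)c1cc2cnc(Nc3ccc(NC(=O)C4(C(=O)Nc5ccccc5F)CC4)cc3)nc2n1C1CCCC1`: 63.4%
- compound 3 `CN(C)C(=O)c1cc2cnc(Nc3ccc(NC(=O)C4(C(=O)Nc5cccc(Cl)c5)CC4)cc3)nc2n1C1CCCC1`: 16.2%

All three were measured in a functional assay on SiHa cells (Homo sapiens) for inhibition, read by CCK-8 assay, with a stated time of 72 h, tested at 1 uM (on this read-out lower numbers stand for less inhibition of growth and higher numbers for more inhibition of growth at the one concentration tested), and compound 3 stands lowest. Next comes compound 4 `CN(C)C(=O)c1cc2cnc(Nc3ccc(NC(=O)C4(C(=O)Nc5ccc(Br)cc5)CC4)cc3)nc2n1C1CCCC1`, with 4-bromophenyl in place of 3-chlorophenyl on an amide-type nitrogen. Going by the values given here, no bromophenyl compound has been measured. The closest guide is compound 1, which carries 4-fluorophenyl, and a number 20.3 percentage points lower from compound 1 to compound 3 (beyond the scatter) was a modest step. The large a number 47.2 percentage points lower from compound 2 to compound 3 (beyond the scatter) shows how widely this series moves with the phenyl group, so the expectation stays loose. A modest rise in this assay is expected, with the estimated step being a number 13.8 percentage points higher from compound 3 to compound 4 (beyond the scatter). Compound 4 is estimated at 30%, with an expected range of 10% to 52%.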

Compound 4, percent growth inhibition at one concentration: 23.2%
For compound 4 the middle estimate is 6.8 percentage points above the measured one; low and high end bracket the measured number.
By their numbers in this assay, from the lowest: compounds 3 and 4 (each within the scatter of the next); then compound 1; then compound 2.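

With the ring place held, swapping only the halogen moves the number, bromo in place of fluoro on an aromatic carbon (a number 13.3 percentage points lower from compound 1 to compound 4 (beyond the scatter)) in this assay. The 4-bromophenyl and 3-chlorophenyl groups on this amide-type nitrogen give readings that cannot be separated (a number 7 percentage points higher from compound 3 to compound 4 (within the scatter)). The 2-fluorophenyl group keeps a wide margin over 4-bromophenyl as well (a number 40.2 percentage points lower from compound 2 to compound 4 (beyond the scatter)). As far as these compounds go, how 2-chlorophenyl or unsubstituted phenyl on this nitrogen would compare remains open. No available evidence bears on what lies behind these steps.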